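The source may report more compounds than this note shows. Statements on the series, on what has been measured and on what is new or still open speak of the compounds shown alone.

Of the compounds shown here, three have so far been measured in an ADME assay for permeability, using PAMPA, at pH 7.4; a lower number here means that the compound crosses the layer more slowly, a higher number that the compound crosses the layer faster. Compound 1 `Cn1cc(-c2ccc(C(F)(F)F)cc2)c2cc(F)c(C(=O)NS(=O)(=O)C3CC3)cc21` gives 323 nm/s. Compound 2 `CC(C)COc1ncc(-c2cn(C)c3cc(C(=O)NS(=O)(=O)C4CC4)c(F)cc23)cc1Cl` gives 310 nm/s, and compound 3 `CC(C)COc1ncc(-c2cn(C)c3cc(C(=O)NS(C)(=O)=O)c(F)cc23)cc1Cl` gives 205 nm/s. Compound 2 and compound 3 differ only by methyl in place of cyclopropyl on a sulfonyl sulfur, and this single change produced a 1.5-fold lower number from compound 2 to compound 3 (0.18 log units; within the scatter). How the core of compound 1 differs from the core of compound 2 is not broken down here; the readings of compound 1 and compound 2, and of compound 1 and compound 3, all lie within the usual scatter of one another.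

Compound 4 `Cn1cc(-c2ccc(C(F)(F)F)cc2)c2cc(F)c(C(=O)NS(C)(=O)=O)cc21` has not yet been measured in this assay. Going by the values given here, it differs from compound 1 by methyl in place of cyclopropyl on a sulfonyl sulfur, which is the same change, in the same place, as the one from compound 2 to compound 3. Because the measured pair showed a 1.5-fold lower number from compound 2 to compound 3 (0.18 log units; within the scatter), a step of about the same size is expected for compound 4, namely a 1.4-fold lower number from compound 1 to compound 4 (0.14 log units; within the scatter). On that basis compound 4 is estimated at 235 nm/s, with a likely range from 150 nm/s to 360 nm/s.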

Compound 4, apparent permeability: 140 nm/s
Beside the measured number, compound 4's estimate is 1.7-fold (0.22 log units) above it; measured number outside the range, below it.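

In this assay, putting methyl in place of cyclopropyl on the sulfonyl sulfur gives a 2.3-fold lower number from compound 1 to compound 4 (0.36 log units; beyond the scatter) in the core of compound 1. The same change has now been seen on two cores, and the two steps cannot be told apart: the same change on two cores in this assay, a 1.5-fold lower number (0.18 log units; within the scatter) from compound 2 to compound 3 and a 2.3-fold lower number (0.36 log units; beyond the scatter) from compound 1 to compound 4, 1.5-fold (0.18 log units) apart, within the scatter of two such steps. So the change can be carried between these two cores with a similar size of step, although only the step on the core of compound 1 is large enough to stand clear of the scatter, and two pairs neither establish a fixed step for every core in the series nor explain why the step arises.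

The compounds shown leave open how a longer chain or an amine on the sulfonyl sulfur would compare with cyclopropyl and methyl. They also leave open whether a step of similar size would appear on a third core, which would be a stronger test of whether this change transfers across the series.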